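Dropping one trifluoromethyl: expected effect on cell inhibition

The compounds below may be only part of what the source reports. "The series", "measured", "known", "first", "only" and "open" are said of these compounds alone.

Of the compounds shown here, two carry numbers so far. Compound 1 `COc1cc(Cl)cc(-c2nn(-c3cccc(NC(=O)Nc4ccc(Cl)c(C(F)(F)F)c4)c3)cc2-c2ccncc2)c1` gives 8.71% in a functional assay on OVCAR-8 cells (Homo sapiens) for inhibition, read by sulforhodamine B assay, with a stated time of 48 h, tested at 10 uM; a lower number here means a stronger effect, a higher number a weaker effect of the compound at the concentration tested. Compound 2 `COc1cc(Cl)cc(-c2nn(-c3cccc(NC(=O)Nc4cc(C(F)(F)F)cc(C(F)(F)F)c4)c3)cc2-c2ccncc2)c1` gives -2.46% in this assay. Compound 2 thus stands lowest of the two numbers, the stronger effect at the tested concentration, and compound 1 lies higher by a margin beyond the usual scatter. For the measured compounds named here, no pair of measured compounds differs in a single place, so no measured step of any kind is available to anchor the next change.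

Compound 3 `COc1cc(Cl)cc(-c2nn(-c3cccc(NC(=O)Nc4cccc(C(F)(F)F)c4)c3)cc2-c2ccncc2)c1` is the compound to be measured next. It differs from compound 2 in one place: hydrogen in place of trifluoromethyl on an aromatic carbon. Without a measured step of this kind to go by, the estimated step of a number 9.5 percentage points higher from compound 2 to compound 3 (within the scatter) is small and upward, a rise that may well stay within the scatter. For compound 3 the estimate in this assay is 7%, with a range from -6% to 24%.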

Compound 3, a percentage reported as activity, at one concentration (the size of the read-out at that concentration, not a potency): -12.3%
The estimate for compound 3 lay 19.3 percentage points above the measured number; measured number below the stated range.
By their numbers in this assay, from the lowest: compounds 3 and 2 (each within the scatter of the next); then compound 1.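

In this assay, hydrogen in place of trifluoromethyl on this aromatic carbon gives a number 9.8 percentage points lower from compound 2 to compound 3 (within the scatter), so the second trifluoromethyl is not needed to keep the number at this level. Hydrogen in place of chloro on an aromatic carbon gives a number 21 percentage points lower from compound 1 to compound 3 (beyond the scatter), the first single-place step in the series to exceed the scatter, and here the chloro goes with the weaker effect at the tested concentration. For the compounds shown here, nothing measured so far accounts for either step.

Open, as far as these compounds go, is whether an amine, a methyl or a nitrile on these aromatic carbons would keep the number of compound 3 or move it. Going by these compounds alone, also open is whether the trifluoromethyl that remains in compound 3 contributes at all, since no step for its replacement is available.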